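Adenosine deaminase series: pyrazinyl replacing fluoro on the aryl ring

A few compounds are considered here, and "the series" means these few. Any claim that something is new, unique, unknown or untested is made for them only; others in the source may bear on it.

Three compounds on a shared core have numbers in an assay on isolated protein for inhibition of adenosine deaminase (Bos taurus), with a stated time of 5 min; on this read-out lower numbers stand for stronger inhibition and higher numbers for weaker inhibition. Compound 1 `C[C@H](O)[C@@H](CCc1ccc(C(F)(F)F)cc1)n1cnc2c(N)ncnc21` gives 5.2 nM in this assay. Compound 2 `C[C@H](O)[C@@H](CCc1ccccc1C(F)(F)F)n1cnc2c(N)ncnc21` gives 6.2 nM in this assay. Compound 3 `C[C@H](O)[C@@H](CCc1cccc(F)c1)n1cnc2c(N)ncnc21` gives 1.6 nM in this assay, the lowest of the three numbers; its gaps to compound 1 and to compound 2 both lie beyond the usual scatter, so compound 3 is the strongest inhibitor among the measured set.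

Compound 4 `C[C@H](O)[C@@H](CCc1cccc(-c2cnccn2)c1)n1cnc2c(N)ncnc21` differs from compound 3 in one place: pyrazin-2-yl in place of fluoro on an aromatic carbon. Within the data shown here, no measured pair shows this kind of exchange, so there is no step to lean on. A ring of six heavy atoms replaces a single fluorine on the aryl group; a modest rise in the number, somewhat beyond the scatter, is expected rather than a gain. The step from compound 3 to compound 4 is estimated as a 3.1-fold higher number from compound 3 to compound 4 (0.49 log units; beyond the scatter) in this assay. Compound 4 is therefore expected to give about 5 nM in this assay, within a range from 1.5 nM to 20 nM.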

Compound 4, inhibition constant: 1.9 nM
Beside the measured number, compound 4's estimate is 2.6-fold (0.42 log units) above it, within the range that was stated.
By their numbers in this assay, from the lowest: compounds 3 and 4 (each within the scatter of the next); then compounds 1 and 2 (each within the scatter of the next).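

In this assay the exchange of fluoro for pyrazin-2-yl gives a 1.2-fold higher number from compound 3 to compound 4 (0.07 log units; within the scatter), so the number does not separate the two groups. This position, on an aromatic carbon meta to a large group, therefore accepts a group of 6 heavy atoms with one six-membered aromatic ring and 2 hydrogen-bond acceptors in place of a single fluorine, with no loss readable beyond the scatter. The data offer no measured basis for explaining this result.

Open, as far as these compounds go, is whether a phenyl ring, which has no ring nitrogen, would read like pyrazin-2-yl on the same aromatic carbon. Also open, from the compounds shown here alone, is how a carboxylic acid or an amine would read there.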